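A few compounds are considered here, and "the series" means these few. Any claim that something is new, unique, unknown or untested is made for them only; others in the source may bear on it.

Values in a functional assay on HepG2 cells (Homo sapiens) for antiproliferative activity, read by MTT assay, with a stated time of 72 h (a lower number here means a stronger inhibitor, a higher number a weaker inhibitor), follow:
- compound 1 `COc1ncc(-c2ccc3c(c2)NC(=O)CO3)cc1NS(=O)(=O)c1ccc(F)cc1` gives 6590 nM
- compound 2 `O=C1COc2ccc(-c3cnc(Cl)c(NS(=O)(=O)c4ccc(F)cc4)c3)cc2N1` gives > 40000 nM (a limit of the assay)
- compound 3 `O=C1COc2ccc(-c3cccc(NS(=O)(=O)c4ccc(F)cc4)c3)cc2N1c1ccccc1` gives 30300 nM

Compound 1 has the lower of the two exact numbers, and compound 3 stands higher. The reading for compound 2 is only a limit (the limit of > 40000 nM in this assay, at which 1 of the 3 values shown sits).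

Compound 4 `COc1ncc(-c2ccc3c(c2)N(C2CC2)C(=O)CO3)cc1NS(=O)(=O)c1ccc(F)cc1`, not yet measured, keeps the core of compound 1 and changes one place: cyclopropyl in place of hydrogen on an amide-type nitrogen in a ring. Within the data shown here, the one measured step, an at least 6.0-fold higher number from compound 1 to compound 2 (0.78 log units; beyond the scatter), lies at a different place, so it bears only indirectly on this change. Among the measured compounds shown here, no step at that nitrogen has been measured. The nearest hint is compound 3, which carries phenyl on that nitrogen but also differs elsewhere, and gives 30300 nM in this assay. On that thin basis, a modest move towards a weaker number is expected. The expected change is a 2.0-fold higher number from compound 1 to compound 4 (0.30 log units; within the scatter). Compound 4 is estimated at 13000 nM, with an expected range from 3500 nM to 40000 nM.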

Compound 4, half-maximal inhibitory concentration: 14400 nM
Compound 4: the middle estimate sits 1.1-fold (0.04 log units) below what was measured; measured number inside the range.
By their numbers in this assay, from the lowest: compound 1; then compound 4; then compound 3. At a limit, above all of these: compound 2.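

Setting cyclopropyl in place of the amide hydrogen on the core of compound 1 gives, in this assay, a clean reading at this nitrogen, which compound 3 could not give, as it also differs elsewhere: a 2.2-fold higher number from compound 1 to compound 4 (0.34 log units; beyond the scatter). The amide hydrogen is therefore not needed for a measurable antiproliferative reading, although the change carries a modest cost. Nothing in the data shown accounts for the size of this step.

On this core, that nitrogen is shown with only hydrogen and cyclopropyl, so it remains open how methyl, a longer alkyl chain, or a chain ending in an amine or a carboxylic acid would read. As far as these compounds go, it is also open whether the step would repeat with chloro in place of methoxy.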